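Changing the acyl group of compound 3

A few compounds are considered here, and "the series" means these few. Any claim that something is new, unique, unknown or untested is made for them only; others in the source may bear on it.

compound 1 `C=CCOc1cc(/C=C/C(=O)c2ccc(OC)c3c2OC(C)(C)C=C3)ccc1OC`: > 10000 nM (a limit)
compound 2 `COc1ccc(/C=C/C(=O)c2ccc(OC)c3c2OC(C)(C)C=C3)cc1OCCO`: > 10000 nM (a limit)
compound 3 `CCCCC(=O)Oc1cc(/C=C/C(=O)c2ccc(OC)c3c2OC(C)(C)C=C3)ccc1OC`: 100 nM

All three were read in a functional assay on HepG2 cells (Homo sapiens) for cytotoxicity, read by MTT assay; on this read-out lower numbers stand for stronger inhibition and higher numbers for weaker inhibition. Among the measured compounds shown here, compound 3, at 100 nM, holds the only actual number. The other two entries are limits. Compound 4 `COc1ccc(/C=C/C(=O)Oc2cc(/C=C/C(=O)c3ccc(OC)c4c3OC(C)(C)C=C4)ccc2OC)cc1` keeps the carbonyl on the same oxygen and differs as follows: 2-(4-methoxyphenyl)ethenyl in place of butyl on a carbonyl carbon. For the measured compounds named here, two measured steps bear on this: an at least 100-fold lower number from compound 1 to compound 3 (2.00 log units; beyond the scatter) and an at least 100-fold lower number from compound 2 to compound 3 (2.00 log units; beyond the scatter). Both install butylcarbonyl on that oxygen, but neither varies the group on the carbonyl carbon, so they support only a cautious expectation. Compound 4 retains the carbonyl, so it is expected to stay nearer compound 3 than the limit, with a modest loss. The expected change is a 4.0-fold higher number from compound 3 to compound 4 (0.60 log units; beyond the scatter). The estimate for compound 4 is 400 nM, within an expected range of 50 nM to 4000 nM.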

Compound 4, half-maximal inhibitory concentration: 430 nM
Estimate against measurement, compound 4: 1.1-fold (0.03 log units) below; the measured number falls inside the stated range.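

In this assay, the group on this carbonyl carbon can change from butyl to 2-(4-methoxyphenyl)ethenyl, which brings in an aromatic ring, at a modest cost: a 4.3-fold higher number from compound 3 to compound 4 (0.63 log units; beyond the scatter). The large gap to the 2-hydroxyethyl and allyl compounds persists with this second acyl group: an at least 23-fold lower number from compound 2 to compound 4 (1.36 log units; beyond the scatter), and an at least 23-fold lower number from compound 1 to compound 4 (1.36 log units; beyond the scatter). Both of those steps start from a limit: the limit of > 10000 nM in this assay, at which 2 of the 4 values shown sit.

Open, on these data alone, is whether a shorter acetyl group or a longer chain on the carbonyl carbon would move the number in either direction. Also open, as far as these compounds go, is how an amine or a carboxylic acid at the end of the butyl chain would read.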